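The source may report more compounds than this note shows. Statements on the series, on what has been measured and on what is new or still open speak of the compounds shown alone.

Measured compounds:
- Compound 1 `Nc1ccnc2c1nc(-c1ccccc1)n2CCN1CCCCC1`: in an assay on isolated protein for inhibition of high affinity 3',5'-cyclic-AMP phosphodiesterase 7A (Homo sapiens), read by cAMP accumulation, with a stated time of 20 min (a lower number here means a stronger inhibitor, a higher number a weaker inhibitor), compound 1 gives > 200000 nM, which is a limit of the assay and not a number.
- Compound 2 `CCCCCn1c(-c2ccccc2)nc2c(N)ccnc21`: in this assay compound 2 gives > 200000 nM, again only a limit.
- Compound 3 `CCCCCn1c(-c2ccco2)nc2c(N)ccnc21`: in this assay compound 3 gives > 200000 nM, also a limit.

Compound 3 therefore stands where every measured compound stands: at the limit, with no number that would set it apart from compound 1 or compound 2. The step from compound 3 to compound 4 `CCCCCn1c(-c2ccco2)nc2c(NCCCOC)ccnc21` is 3-methoxypropyl in place of hydrogen on a nitrogen on an aromatic ring. Among the compounds with values here, two measured steps bear on the question of how such changes move the read-out: a step that the two limits leave unreadable from compound 1 to compound 2 and a step that the two limits leave unreadable from compound 2 to compound 3. Neither gives a size, because of the limit of > 200000 nM in this assay, at which 3 of the 3 values shown sit, so they set no scale for what a change at the amine nitrogen might do. The only fair expectation for the step from compound 3 to compound 4 is an at least 2.0-fold lower number from compound 3 to compound 4 (0.30 log units; that floor lies within the scatter), wide and uncertain. Compound 4 is thus estimated at 100000 nM in this assay, with a range from 5000 nM to 300000 nM.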

Compound 4, half-maximal inhibitory concentration: 34200 nM
Beside the measured number, compound 4's estimate is 2.9-fold (0.47 log units) above it; low and high end bracket the measured number.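

In this assay, within the data shown here, the change to 3-methoxypropyl in place of hydrogen on a nitrogen on an aromatic ring is the first step whose direction can be read: an at least 5.8-fold lower number from compound 3 to compound 4 (0.76 log units; beyond the scatter). The earlier steps shown here cannot be read, so only now is there a sign that this nitrogen can carry a chain and that a change here can bring inhibition within the range of the assay. The size of the step remains a floor, because compound 3 has only a limit and no number: the limit of > 200000 nM in this assay, at which 3 of the 4 values shown sit.

The compounds shown do not tell whether the chain's length or its oxygen matters, which a plain propyl chain or a longer chain ending in an amine could help to separate. Also open, as far as these compounds go, is whether 3-methoxypropyl would give a similar step with phenyl in place of furan-2-yl.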